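Swapping One Small Ring for Another on a Sulfonyl Side Chain

The source may hold more compounds than are shown below. What is called first, only, known or untested is meant among the compounds shown, and "the series" means these compounds.

Measured so far:
Compound 1, `O=S(=O)(CC1=NCCO1)C1C(c2ccc(Cl)cc2)=NOC1c1ccc(Cl)cc1`, is reported as "not active" (no number reported) in a functional assay, read by Griess assay, with a stated time of 150 min, tested at 75 ug/mL; a higher number here means a stronger effect of the compound at the concentration tested, a lower number a weaker effect.
Compound 2, `COc1ccc(C2=NOC(c3ccc(C)cc3)C2S(=O)(=O)CC2=NCCO2)cc1`, gives 65.9% in this assay.
Compound 3, `COc1ccc(C2=NOC(c3ccc(C)cc3)C2S(=O)(=O)CC2=NCCS2)cc1`, gives 54.1% in this assay.

Compounds 2 and 3 share one core and differ only in the small ring attached to the saturated chain carbon bound to the sulfonyl sulfur: a group of 5 heavy atoms (3 carbon, 1 nitrogen, 1 sulfur; one five-membered non-aromatic ring with 2 hetero atoms) in place of a group of 5 heavy atoms (3 carbon, 1 nitrogen, 1 oxygen; one five-membered non-aromatic ring with 2 hetero atoms), on a saturated chain carbon bound to a sulfonyl sulfur. This change produced a number 11.8 percentage points lower from compound 2 to compound 3 (beyond the scatter), a modest fall that still lies beyond the usual scatter.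

Compound 4, `O=S(=O)(CC1=NCCS1)C1C(c2ccc(Cl)cc2)=NOC1c1ccc(Cl)cc1`, is not yet measured. It is related to compound 1 in the same way: a group of 5 heavy atoms (3 carbon, 1 nitrogen, 1 sulfur; one five-membered non-aromatic ring with 2 hetero atoms) in place of a group of 5 heavy atoms (3 carbon, 1 nitrogen, 1 oxygen; one five-membered non-aromatic ring with 2 hetero atoms), on a saturated chain carbon bound to a sulfonyl sulfur. The place of the change is described in the same words for both pairs, so the change itself is the same. The two cores, however, differ from each other, and that difference between the core of compound 1 and the core of compound 2 is not broken down here.

For compound 1 no number is available in this assay, only a report of no activity. Going by the values given here, the one measured example of this change, from compound 2 to compound 3, lowered the read-out modestly. Starting from a compound already reported as not active, a step of similar direction and size would be expected to leave compound 4 at a low read-out as well, quite possibly again reported without a number. Compound 4 is therefore estimated at 8% in this assay, with a likely range from 0% to 25%.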

Compound 4, a percentage reported as activity, at one concentration (the size of the read-out at that concentration, not a potency): "not active" (no number reported)
The entry for compound 4 holds no number, so the estimate cannot be set against anything.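

In this assay compound 1 gives "not active" (no number reported) and compound 4 gives "not active" (no number reported) as well, so no step can be read between these two compounds. No measured evidence bears on this result. The compounds shown leave open whether exchanging the oxygen-containing ring for the sulfur-containing ring changes the read-out at all on the core of compound 1.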